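This account rests on a few compounds, and the source may have more. Where it says the series, first, only, none or still open, it means among the compounds named here.

Measured in a functional assay on Panc203 cells (Homo sapiens) for cytotoxicity, read by MTT assay; on this read-out higher numbers stand for weaker inhibition and lower numbers for stronger inhibition:
- Compound 1 `O=C(NC(=O)c1ccccc1)Nc1ccc(Sc2ncccn2)cc1`: "not determined" (no result reported)
- Compound 2 `O=C(NC(=S)Nc1ccc(Oc2ncccn2)cc1)c1ccccc1`: "not determined" (no result reported)
- Compound 3 `O=C(NC(=O)c1ccccc1)Nc1ccc(Sc2ncc(Br)cn2)cc1`: 7500 nM

Compound 2 has no place on the scale, since its entry reads "not determined" (no result reported), and compound 1 also lacks a number. Compound 4 `O=C(NC(=S)Nc1ccc(Sc2ncc(Br)cn2)cc1)c1ccccc1` has yet to be measured. It carries (5-bromopyrimidin-2-yl)sulfanyl in place of (pyrimidin-2-yl)oxy on an aromatic carbon. Within the data shown here, no step from compound 2 can be sized in this assay. Among the measured compounds shown here, the only guide is compound 3, which carries the same entering group and gives 7500 nM. A result near that value is expected, with no shift beyond the usual scatter. For compound 4 the estimated value is 6000 nM, with an expected range of 2000 nM to 20000 nM.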

Compound 4, half-maximal inhibitory concentration: > 10000 nM
Compound 4 ended at the assay's limit; the forecaster's own chance of this, stated with the estimate: 15%; middle value at least 1.6-fold (0.22 log units) away from the limit.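

In this assay compound 4 reaches a limit of the assay, > 10000 nM, rather than a number. Among these compounds, compound 2 has no value, so no step from compound 2 to compound 4 can be read. As far as these compounds go, what replacing (pyrimidin-2-yl)oxy with (5-bromopyrimidin-2-yl)sulfanyl does to cytotoxicity remains open.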